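Cytotoxicity series: triazole side chain replaced by aminoalkyl chain

The compounds below may be only part of what the source reports. "The series", "measured", "known", "first", "only" and "open" are said of these compounds alone.

Measured compounds:
Compound 1, `O=C1c2c[n+]([O-])c3ccccc3c2C(=O)c2c1c1ccccc1n2Cc1cn([C@H]2C[C@H](O)[C@@H](CO)O2)nn1`, 530 nM in a functional assay on MCF7 cells (Homo sapiens) for cytotoxicity, read by MTT assay, with a stated time of 72 h; a lower number here means a stronger inhibitor, a higher number a weaker inhibitor
Compound 2, `O=C1c2c[n+]([O-])c3ccccc3c2C(=O)c2c1c1ccccc1n2Cc1cn(CC(O)CO)nn1`, 1110 nM in this assay
Compound 3, `CC1(C)OC[C@H](Cn2cc(Cn3c4c(c5ccccc53)C(=O)c3c[n+]([O-])c5ccccc5c3C4=O)nn2)O1`, 530 nM in this assay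

Compound 2 carries the highest of the three numbers in this assay. Its nearest neighbour is compound 1, reached by a 2.1-fold higher number from compound 1 to compound 2 (0.32 log units; beyond the scatter); the step to compound 3 is a 2.1-fold lower number from compound 2 to compound 3 (0.32 log units; beyond the scatter). Compound 1 and compound 3 give numbers that are indistinguishable at the digits recorded, as no change at the digits printed from compound 1 to compound 3 (within the scatter) shows. All three measured changes touch only the group on the triazole nitrogen; the triazole itself and the rest of the shared core are kept.

Compound 4, `CN(C)CCCCCn1c2c(c3ccccc31)C(=O)c1c[n+]([O-])c3ccccc3c1C2=O`, is not yet measured. Its difference from compound 2 is 4-(dimethylamino)butyl in place of 1-(2,3-dihydroxypropyl)-1H-1,2,3-triazol-4-yl on a saturated chain carbon bound to an aromatic nitrogen. Here the triazole leaves altogether and a chain bearing a dimethylamino group enters. Going by the values given here, none of the measured steps changes this part of the molecule, so they bear on compound 4 only indirectly: they show that the group attached to the aromatic nitrogen can be varied with modest effect on this assay. The expectation for compound 4 is a step of a 1.9-fold lower number from compound 2 to compound 4 (0.27 log units; within the scatter) from compound 2, with broad uncertainty. Compound 4 is estimated at 600 nM, range 150 nM to 2500 nM, in this assay.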

Compound 4, half-maximal inhibitory concentration: 200 nM
Estimate against measurement, compound 4: 3.0-fold (0.48 log units) above; measured number inside the range.
By their numbers in this assay, from the lowest: compound 4; then compounds 1 and 3 (each within the scatter of the next); then compound 2.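

Working notes: in this assay, the triazole is not needed for a number in this range, since replacing 1-(2,3-dihydroxypropyl)-1H-1,2,3-triazol-4-yl with 4-(dimethylamino)butyl gives a 5.6-fold lower number from compound 2 to compound 4 (0.74 log units; beyond the scatter). This is the largest step printed for the series, whereas the earlier steps, which changed only the group on the triazole nitrogen, reached no further than a 2.1-fold higher number from compound 1 to compound 2 (0.32 log units; beyond the scatter), so among these compounds, replacing the whole side chain moves the number more than varying that group alone. No data are available to explain why this change lowers the number.

The step removes the triazole and the two hydroxyl groups and brings in the dimethylamino group all at once, so the compounds shown do not separate the contribution of each part. A plain pentyl chain, a primary amine, a morpholine or pyrrolidine in place of the dimethylamino group, and a shorter or longer chain carrying the same dimethylamino group would each help to show which part of the change matters.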